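This account rests on a few compounds, and the source may have more. Where it says the series, first, only, none or still open, it means among the compounds named here.

Compound 1 `CC(=O)O[C@H](CC/C(C)=C/[C@@H](O)C/C(C)=C/CCc1ccoc1)[C@]1(C)CCC(=O)O1`: 5400 nM
Compound 2 `CC(=O)O[C@H](/C=C(\C)CC[C@@H](O)[C@]1(C)CCC(=O)O1)C/C(C)=C/CCc1ccoc1`: 9600 nM

In a functional assay on K562 cells (Homo sapiens) for cytotoxicity, read by XTT assay (on this read-out higher numbers stand for weaker inhibition and lower numbers for stronger inhibition), compound 2 gives 9600 nM, a number that the usual scatter cannot separate from compound 1 at 5400 nM. Compound 3 `CC(=O)O[C@H](/C=C(\C)CC[C@@H](OC(C)=O)[C@]1(C)CCC(=O)O1)C/C(C)=C/CCc1ccoc1` differs from compound 2 by acetyl in place of hydrogen on an oxygen on a saturated carbon, or hydroxy to acetoxy. Among the measured compounds shown here, no measured pair shows this change, so no step beyond the scatter is expected in this assay. The estimated 1.4-fold lower number from compound 2 to compound 3 (0.14 log units; within the scatter) is small and leans slightly toward a lower number. For compound 3 the expected value is 7000 nM, with an estimated range of 2500 nM to 20000 nM.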

Compound 3, half-maximal inhibitory concentration: 10200 nM
The estimate for compound 3 lay 1.5-fold (0.16 log units) below the measured number; the measured number falls inside the stated range.
By their numbers in this assay, from the lowest: compounds 1, 2 and 3 (each within the scatter of the next).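

In this assay acetyl in place of hydrogen on the oxygen gives a 1.1-fold higher number from compound 2 to compound 3 (0.03 log units; within the scatter) and, on the other hydroxy group, a 1.9-fold higher number from compound 1 to compound 3 (0.28 log units; within the scatter) in the same assay. Compound 1 and compound 2 each carry one free hydroxy group and one acetoxy group, whereas compound 3 carries two acetoxy groups, so a free hydroxy group at either of these places is not required for cytotoxicity at this level. Nothing available explains this result.

As far as these compounds go, whether a longer acyl chain such as butyryl on that oxygen, or an amine in place of the hydroxy group, would keep the number within the scatter remains open.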